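Ethyl for hydrogen on a saturated ring carbon

The compounds below may be only part of what the source reports. "The series", "measured", "known", "first", "only" and "open" are said of these compounds alone.

Compound 1 `O=C1c2ccc(Cl)cc2CN1c1cccnc1` and compound 2 `CCC1c2cc(Cl)ccc2C(=O)N1c1cccnc1` share one core, compound 2 showing (ethyl in place of hydrogen on a saturated ring carbon). In an ADME assay on cells for inhibition of cytochrome P450 11B1, mitochondrial (Homo sapiens), read by HTRF (a higher number here means a weaker inhibitor, a lower number a stronger inhibitor), compound 1 gives 10700 nM and compound 2 gives 3340 nM, a step of a 3.2-fold lower number from compound 1 to compound 2 (0.51 log units; beyond the scatter). Compound 3 `CCC(=O)N[C@@H]1CCCc2c1cncc2N1Cc2cc(Cl)ccc2C1=O` has a different core; the difference between the two cores is not broken down here. In this assay compound 3 gives 5210 nM. Compound 4 `CCC(=O)N[C@@H]1CCCc2c1cncc2N1C(=O)c2ccc(Cl)cc2[C@H]1CC` is not yet measured; against compound 3 it shows (ethyl in place of hydrogen on a saturated ring carbon). For the measured compounds named here, this is the same kind of change as the one from compound 1 to compound 2, though around the place the ring atom next to it bears a pyridin-3-yl group in compound 2 and a large group in compound 4. Resting on the step of a 3.2-fold lower number from compound 1 to compound 2 (0.51 log units; beyond the scatter), the step expected here is a 3.1-fold lower number from compound 3 to compound 4 (0.49 log units; beyond the scatter). Compound 4 is estimated at 1700 nM, expected between 700 nM and 4200 nM.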

Compound 4, half-maximal inhibitory concentration: 10200 nM
Compound 4: the middle estimate sits 6.0-fold (0.78 log units) below what was measured; measured number above the stated range.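

In this assay, ethyl in place of hydrogen on a saturated ring carbon gives a 2.0-fold higher number from compound 3 to compound 4 (0.29 log units; within the scatter), and the gain seen on the core of compound 1 does not carry over to the core of compound 3: the same change on two cores in this assay, a 3.2-fold lower number (0.51 log units; beyond the scatter) from compound 1 to compound 2 and a 2.0-fold higher number (0.29 log units; within the scatter) from compound 3 to compound 4, 6.3-fold (0.80 log units) apart, beyond the scatter of two such steps

The change therefore cannot be assumed to lower the number on another core in this series. With a single pair on each core, these data do not show which difference between the cores accounts for the gap, nor how the change would behave on any further core.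

From the compounds shown here alone, it remains open whether a methyl or a longer chain such as propyl on the same ring carbon would follow the step on the core of compound 1 or the one on the core of compound 3. Going by these compounds, the effect of a hydroxyl or an amine at that place also remains open.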